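Three limits and a fourth hydroxyphenyl analogue

The source may hold more compounds than are shown below. What is called first, only, known or untested is meant among the compounds shown, and "the series" means these compounds.

Compound 3 `Oc1ccccc1-c1cc(-c2cccc(OC(F)(F)F)c2)cc(-c2ccccc2O)n1` gives in a functional assay on HCT-15 cells (Homo sapiens) for inhibition (a higher number here means a weaker inhibitor, a lower number a stronger inhibitor), only a limit, > 50000 nM. Compound 1 `Oc1ccccc1-c1cc(-c2cccc(F)c2)cc(-c2ccccc2O)n1` in this assay also sits at a limit, > 50000 nM. Compound 2 `Oc1ccc(-c2cc(-c3cccc(C(F)(F)F)c3)cc(-c3ccccc3O)n2)cc1` in this assay likewise reaches only a limit, > 50000 nM. The step from compound 1 to compound 3, a step that the two limits leave unreadable from compound 1 to compound 3, is therefore unreadable: with both ends at a limit, its size cannot be taken from the numbers. Compound 3 thus stands nowhere on a scale that the numbers fix; all that is known of it is the limit of > 50000 nM in this assay, at which 3 of the 3 values shown sit.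

Compound 4 `Oc1ccc(-c2cc(-c3cccc(OC(F)(F)F)c3)cc(-c3ccccc3O)n2)cc1` differs from compound 3 in one place: 4-hydroxyphenyl in place of 2-hydroxyphenyl on an aromatic carbon. Among the measured compounds shown here, no measured step bears on this change directly; compound 2 carries the 4-hydroxyphenyl group and compound 3 the 2-hydroxyphenyl group, and their two values show only that both sit at the limit. For the measured compounds named here, the one step measured, from compound 1 to compound 3, is unreadable, so neither size nor direction can be drawn from it. With nothing in the series read as a number, compound 4 is expected to remain at the limit as well, an expected step of a number no higher from compound 3 to compound 4 (the limit leaves the size open) without readable size. The estimate for compound 4 in this assay is therefore 50000 nM, within 20000 nM to 100000 nM, with a limit again the most likely report.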

Compound 4, half-maximal inhibitory concentration: > 50000 nM
Compound 4 ended at the assay's limit; the forecaster's own chance of this, stated with the estimate: 85%; the middle value lies on the limit itself.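

Neither the step from compound 3 to compound 4 nor the step from compound 2 to compound 4 can be read in this assay, and the series gains no number: the limit of > 50000 nM in this assay, at which 4 of the 4 values shown sit.

The compounds shown leave open whether 4-hydroxyphenyl in place of 2-hydroxyphenyl, or trifluoromethoxy in place of trifluoromethyl, changes inhibition at all.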